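Taking the acetamido group off compound 3

The compounds below may be only part of what the source reports. "The series", "measured", "known", "first", "only" and "open" are said of these compounds alone.

In a functional assay on WM164 cells (Homo sapiens) for antiproliferative activity, read by sulforhodamine B assay, with a stated time of 48 h (on this read-out higher numbers stand for weaker inhibition and lower numbers for stronger inhibition), compound 3 `CCCCCCCCCCCCCCCCNC(=O)[C@@H]1CSC(c2ccc(NC(C)=O)cc2)N1` gives 600 nM, and compound 2 `CCCCCCCCCCCCCCNC(=O)[C@@H]1CSC(c2ccc(NC(C)=O)cc2)N1` gives the same number, 600 nM. Compound 1 `CCCCCCCCCCCCCCCCNC(=O)[C@@H]1CSC(c2cc(OC)c(OC)c(OC)c2)N1` gives 700 nM, which is within the usual scatter of compound 3. The numbers therefore place compound 3 level with compound 2 and do not separate it from compound 1.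

The next structure, compound 4 `CCCCCCCCCCCCCCCCNC(=O)[C@@H]1CSC(c2ccccc2)N1`, has hydrogen in place of acetamido on an aromatic carbon. The same difference can be read as 4-acetamidophenyl to phenyl.

Two measured steps offer guidance. The closer one changes the same aromatic group, with 4-acetamidophenyl in place of 3,4,5-trimethoxyphenyl, and amounts to a 1.2-fold lower number from compound 1 to compound 3 (0.07 log units; within the scatter). The other alters only the saturated chain, and shows no change at the digits printed from compound 2 to compound 3 (within the scatter). Neither step tests a phenyl ring with no added group, so the evidence is indirect and the range must stay wide.

Since the closer step stayed within the scatter, no clear shift is expected in this assay, only a slight lean towards a higher number. The expected change is a 1.7-fold higher number from compound 3 to compound 4 (0.22 log units; within the scatter). For compound 4 the estimated value is 1000 nM, with an expected range of 400 nM to 2500 nM.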

Compound 4, half-maximal inhibitory concentration: 700 nM
Estimate against measurement, compound 4: 1.4-fold (0.15 log units) above; low and high end bracket the measured number.
By their numbers in this assay, from the lowest: compounds 2, 3, 1 and 4 (each within the scatter of the next).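

In this assay, taking the acetamido group off the ring gives a 1.2-fold higher number from compound 3 to compound 4 (0.07 log units; within the scatter), so this place on the aromatic ring, para to a large group, can lose all four heavy atoms of acetamido, along with its hydrogen-bond donor and acceptor, without the number leaving the scatter. Within the data shown here, the earlier compounds compared only two substituted rings, whereas the bare phenyl ring now gives no change at the digits printed from compound 1 to compound 4 (within the scatter), which leaves phenyl, 4-acetamidophenyl and 3,4,5-trimethoxyphenyl not told apart in this assay. Nothing in the data shown explains why these aromatic groups sit so close together.

Still open, on these data alone, is whether a carboxylic acid or an amine at this same place on the ring, or a cyclohexyl group in place of the phenyl ring, would also stay within the scatter of compound 4. Among these compounds, the part played by the saturated chain is open too, since the one step along it stays within the scatter and a much shorter chain, such as butyl, could behave quite differently from the long chains seen here.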